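The source may report more compounds than this note shows. Statements on the series, on what has been measured and on what is new or still open speak of the compounds shown alone.

Measured in a functional assay on KB cells (Homo sapiens) for inhibition, with a stated time of 72 h; a higher number here means a weaker inhibitor, a lower number a stronger inhibitor:
compound 1 `COc1ccc(S(=O)(=O)N2CCc3cccc(-c4ccc(F)cc4)c32)cc1`: 86 nM
compound 2 `COc1ccc(-c2cccc3c2N(S(=O)(=O)c2ccc(OC)cc2)CC3)cc1`: 337 nM
compound 3 `COc1ccc(S(=O)(=O)N2CCc3cccc(-c4ccccc4)c32)cc1`: 120 nM

Compound 1 and compound 3 sit level: a 1.4-fold higher number from compound 1 to compound 3 (0.14 log units; within the scatter) stays within the scatter. Compound 2 stands apart, with a 3.9-fold higher number from compound 1 to compound 2 (0.59 log units; beyond the scatter) and a 2.8-fold lower number from compound 2 to compound 3 (0.45 log units; beyond the scatter), both modest and beyond the scatter.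

The unmeasured compound 4 `COc1ccc(S(=O)(=O)N2CCc3cccc(-c4cccs4)c32)cc1` has thiophen-2-yl in place of 4-fluorophenyl on the same aromatic carbon of the core: thiophen-2-yl in place of 4-fluorophenyl on an aromatic carbon. The three measured steps bear on this only indirectly. Among the compounds with values here, each swaps a substituent on the phenyl ring that leaves here, and none replaces that ring, so no direct precedent exists for the change. Removing the fluoro group gave a 1.4-fold higher number from compound 1 to compound 3 (0.14 log units; within the scatter), so the fluoro group has no shown effect beyond the scatter, and only the methoxy group moved the number further.

A small upward move is expected, and the estimated 1.5-fold higher number from compound 1 to compound 4 (0.18 log units; within the scatter) probably stays within the scatter. Compound 4 is estimated at 130 nM, with an expected range of 55 nM to 320 nM.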

Compound 4, half-maximal inhibitory concentration: 215 nM
Compound 4: middle estimate off by 1.7-fold (0.22 log units), on the low side; the range from low to high includes it.
By their numbers in this assay, from the lowest: compounds 1, 3, 4 and 2 (each within the scatter of the next, the first and the last beyond it).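

The first replacement of the whole ring at this position, rather than of a substituent on it, keeps the number in the range of the aryl compounds: thiophen-2-yl in place of 4-fluorophenyl gives a modest step beyond the scatter (a 2.5-fold higher number from compound 1 to compound 4 (0.40 log units; beyond the scatter)) in this assay. Against the other two aryl groups the same ring stays within the scatter, both for phenyl (a 1.8-fold higher number from compound 3 to compound 4 (0.25 log units; within the scatter)) and for 4-methoxyphenyl (a 1.6-fold lower number from compound 2 to compound 4 (0.20 log units; within the scatter)), so only the comparison with 4-fluorophenyl separates it. No measurement on hand accounts for these steps.

Open, on these data alone, is whether a six-membered aromatic ring holding nitrogen, such as pyridin-3-yl, or the isomeric thiophen-3-yl would sit with these compounds. Also open, as far as these compounds go, is how a saturated ring such as morpholine, or an amine or carboxylic acid on the ring, would read at this position.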